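This account rests on a few compounds, and the source may have more. Where it says the series, first, only, none or still open, it means among the compounds named here.

Working notes on the series. Compound 1 `O=C(NC1CCCCC1)C1CCN(Cc2ccc(Cl)cc2)CC1` gives 7.7 nM in an assay for displacement of a labelled ligand from Sigma non-opioid intracellular receptor 1 (Cavia porcellus); a higher number here means a weaker inhibitor, a lower number a stronger inhibitor; compound 3 `O=C(NC1CCCCC1)C1CCN(Cc2ccccc2)CC1` gives 15 nM in this assay. The step between them, (hydrogen in place of chloro on an aromatic carbon), reads a 1.9-fold higher number from compound 1 to compound 3 (0.29 log units; within the scatter). Compound 2 `O=C(C1CCN(Cc2ccc(Cl)cc2Cl)CC1)N1CCCc2ccccc21` gives 138 nM in this assay; how its core differs from that of compound 1 is not broken down here, and the two values alone show compound 2 with the higher number. Compound 4 `O=C(C1CCN(Cc2ccc(Cl)cc2)CC1)N1CCCc2ccccc21` is not yet measured. It differs from compound 2 by hydrogen in place of chloro on an aromatic carbon. This is the same kind of change as from compound 1 to compound 3, but the place differs: there the leaving chloro stood para to a large group, here it stands ortho to a large group and meta to a chloro group. Resting on a 1.9-fold higher number from compound 1 to compound 3 (0.29 log units; within the scatter), a small step of a 1.4-fold lower number from compound 2 to compound 4 (0.14 log units; within the scatter) is expected, with compound 4 estimated at 100 nM (expected range 40 nM to 300 nM).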

Compound 4, inhibition constant: 3.7 nM
Compound 4: middle estimate off by 27-fold (1.43 log units), on the high side; the whole stated range lies above it.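

In this assay, the change from 2,4-dichlorobenzyl to 4-chlorobenzyl gives a 37-fold lower number from compound 2 to compound 4 (1.57 log units; beyond the scatter), so hydrogen in place of chloro on an aromatic carbon does not carry the same size of step between these two cores: the same change on two cores in this assay, a 1.9-fold higher number (0.29 log units; within the scatter) from compound 1 to compound 3 and a 37-fold lower number (1.57 log units; beyond the scatter) from compound 2 to compound 4, 73-fold (1.86 log units) apart, beyond the scatter of two such steps

This does not show what sets the two steps apart. Going by these compounds alone, the chloro leaving compound 2 stands ortho to a large group and meta to a chloro group, a different place from the one leaving compound 1, and the cores differ too, so place and core remain inseparable here. Within the data shown here, each core supplies only one pair, which supports no general rule.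

Open, from the compounds shown here alone, is how a 2,4-dichlorobenzyl group reads on the core of compound 1, and a plain benzyl group on the core of compound 2. Also open, going by these compounds, is how a fluoro or methoxy group would read at the place of the leaving chloro.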